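Ether series: aromatic tail replaced by a plain alkyl chain

The compounds below may be only part of what the source reports. "The series", "measured", "known", "first", "only" and "open" are said of these compounds alone.

Measured so far:
compound 1 `COc1ccc(CCCN2CCC(COC(c3ccccc3)c3ccc(Cl)cc3)CC2)cc1`, 200 nM
compound 2 `COc1cccc(CCCN2CCC(COC(c3ccccc3)c3ccccc3)CC2)c1`, 1500 nM

In a functional assay on cells (T-cell line, Homo sapiens) for inhibition (a lower number here means a stronger inhibitor, a higher number a weaker inhibitor), compound 2 gives 1500 nM, the highest number of the two, and compound 1 gives 200 nM, a gap beyond the scatter. Compound 3 `CCCCCCN1CCC(COC(c2ccccc2)c2ccccc2)CC1` differs from compound 2 by propyl in place of 3-methoxyphenyl on a saturated chain carbon, three bonds along the chain from an amine nitrogen in a ring. Both measured compounds carry an aromatic tail, so nothing measured isolates this change. The step of a 2.0-fold higher number from compound 2 to compound 3 (0.30 log units; within the scatter) is expected to run toward a higher number, of modest size and possibly within the scatter. For compound 3 in this assay the estimate is 3000 nM, with a range from 800 nM to 12000 nM.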

Compound 3, half-maximal inhibitory concentration: 5500 nM
The estimate for compound 3 lay 1.8-fold (0.26 log units) below the measured number; the range from low to high includes it.
By their numbers in this assay, from the lowest: compound 1; then compound 2; then compound 3.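

In this assay, the step of a 3.7-fold higher number from compound 2 to compound 3 (0.56 log units; beyond the scatter) comes with propyl in place of 3-methoxyphenyl on a saturated chain carbon, three bonds along the chain from an amine nitrogen in a ring. This pair isolates the tail: the aromatic group gives the lower number, yet compound 3 still has a measurable value with a plain alkyl chain. No supporting data bear on the origin of this step. Open, going by these compounds, is whether the ring or its methoxy group matters: an unsubstituted phenyl would separate them, and a longer alkyl chain would test chain length.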